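Swapping a Cyclic Amide Back for a Benzylamide

The source may report more compounds than this note shows. Statements on the series, on what has been measured and on what is new or still open speak of the compounds shown alone.

Of the compounds shown here, three sharing one core have been tested in an assay on microsomes from liver for inhibition of 3-hydroxy-3-methylglutaryl-coenzyme A reductase (Rattus norvegicus); a higher number here means a weaker inhibitor, a lower number a stronger inhibitor. Compound 1 `CC(C)c1c(C(=O)NCc2cccc(F)c2F)nn(-c2ccc(F)cc2)c1OC[C@@H](O)C[C@@H](O)CC(=O)O` gives 2 nM, compound 2 `CC(C)c1c(C(=O)N2CCCC2c2ccccc2)nn(-c2ccc(F)cc2)c1OC[C@@H](O)C[C@@H](O)CC(=O)O` gives 14 nM, and compound 3 `CC(C)c1c(C(=O)N2CCC[C@H](c3ccccc3)C2)nn(-c2ccc(F)cc2)c1OC[C@@H](O)C[C@@H](O)CC(=O)O` gives 4.8 nM. Compound 3 therefore stands in the middle: a 2.4-fold higher number from compound 1 to compound 3 (0.38 log units; beyond the scatter), while a 2.9-fold lower number from compound 2 to compound 3 (0.46 log units; beyond the scatter). The largest step seen is a 7.0-fold higher number from compound 1 to compound 2 (0.85 log units; beyond the scatter).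

Compound 4 `COc1ccccc1CNC(=O)c1nn(-c2ccc(F)cc2)c(OC[C@@H](O)C[C@@H](O)CC(=O)O)c1C(C)C` is the next to be measured. Its change from compound 3 is (2-methoxybenzyl)amino in place of 3-phenylpiperidin-1-yl on a carbonyl carbon. This undoes the kind of change seen between compound 1 and compound 3, replacing a cyclic amine on the carbonyl with an amide bearing a benzyl group, as in compound 1. Within the data shown here, the only bearing steps are a 2.4-fold higher number from compound 1 to compound 3 (0.38 log units; beyond the scatter) and a 7.0-fold higher number from compound 1 to compound 2 (0.85 log units; beyond the scatter), both modest and both favouring the benzylamide. A modest drop in the number, beyond the scatter, is therefore expected for compound 4, as a 1.6-fold lower number from compound 3 to compound 4 (0.20 log units; within the scatter). Compound 4 is estimated at 3 nM, with a range from 1 nM to 10 nM.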

Compound 4, half-maximal inhibitory concentration: 22 nM
The estimate for compound 4 lay 7.3-fold (0.87 log units) below the measured number, and the stated range ends below it.
By their numbers in this assay, from the lowest: compound 1; then compound 3; then compounds 2 and 4 (each within the scatter of the next).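

The benzylamide does not carry the low number on its own. Moving from the cyclic amide to the (2-methoxybenzyl)amino group gives a 4.6-fold higher number from compound 3 to compound 4 (0.66 log units; beyond the scatter) and so a loss rather than a gain, while replacing 2-phenylpyrrolidin-1-yl with the same group gives a 1.6-fold higher number from compound 2 to compound 4 (0.20 log units; within the scatter) and no real difference. The substituents on the benzyl ring matter greatly, since 2-methoxyphenyl in place of 2,3-difluorophenyl produces an 11-fold higher number from compound 1 to compound 4 (1.04 log units; beyond the scatter) and this is the largest step in the set.

As far as these compounds go, whether that loss comes from adding the methoxy group or from removing the fluorines stays open, and a plain benzyl or a 2-fluorobenzyl group on the same amide nitrogen would help separate the two. No measurement available here explains why the ring substituents have so strong an effect.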